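Pyridin-3-yl in place of 4-methylphenyl on the hydrazone

The compounds below may be only part of what the source reports. "The series", "measured", "known", "first", "only" and "open" are said of these compounds alone.

Measured compounds:
- compound 1 `C/C(=N\Nc1ncc(Cl)c(Nc2cccc(NC(=O)/C=C/CN(C)C)c2)n1)c1ccc(F)cc1`: 10200 nM
- compound 2 `C/C(=N\Nc1ncc(Cl)c(Nc2cccc(NC(=O)/C=C/CN(C)C)c2)n1)c1ccc(F)cc1F`: 3460 nM
- compound 3 `C/C(=N\Nc1ncc(Cl)c(Nc2cccc(NC(=O)/C=C/CN(C)C)c2)n1)c1ccc(C)cc1`: 11800 nM

In an ADME assay on HT-29 cells (Homo sapiens) for inhibition, read by MTT assay, with a stated time of 72 h (on this read-out higher numbers stand for weaker inhibition and lower numbers for stronger inhibition), compound 3 gives the highest of the three numbers, meaning the weakest inhibition. Its nearest neighbour is compound 1, and the step of a 1.2-fold higher number from compound 1 to compound 3 (0.06 log units; within the scatter) lies within the scatter, so these two cannot be told apart. Compound 2 stands furthest away: the step of a 3.4-fold higher number from compound 2 to compound 3 (0.53 log units; beyond the scatter) is modest but beyond the scatter, and likewise a 2.9-fold lower number from compound 1 to compound 2 (0.47 log units; beyond the scatter) shows compound 2 apart from compound 1.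

Compound 4 `C/C(=N\Nc1ncc(Cl)c(Nc2cccc(NC(=O)/C=C/CN(C)C)c2)n1)c1cccnc1` has not yet been measured in this assay. The change from compound 3 is pyridin-3-yl in place of 4-methylphenyl on a carbon with a double bond to nitrogen. Among the compounds with values here, no measured step swaps an aromatic ring of carbon only for one with a hetero atom, so none bears directly on this change. The two steps that alter this same ring, a 1.2-fold higher number from compound 1 to compound 3 (0.06 log units; within the scatter) and a 3.4-fold higher number from compound 2 to compound 3 (0.53 log units; beyond the scatter), were either within the scatter or modest, which suggests a small effect at most. The step of a 1.3-fold lower number from compound 3 to compound 4 (0.12 log units; within the scatter) is therefore expected to stay within the scatter. Compound 4 is estimated to give 9000 nM in this assay, with a range from 3000 nM to 27000 nM.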

Compound 4, half-maximal inhibitory concentration: 9660 nM
Compound 4: middle estimate off by 1.1-fold (0.03 log units), on the low side; the range from low to high includes it.
By their numbers in this assay, from the lowest: compound 2; then compounds 4, 1 and 3 (each within the scatter of the next).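

In this assay, the step of a 1.2-fold lower number from compound 3 to compound 4 (0.09 log units; within the scatter) and the step of a 1.1-fold lower number from compound 1 to compound 4 (0.02 log units; within the scatter) both lie within the scatter, so on the carbon with a double bond to nitrogen, a six-membered aromatic ring with a hetero atom and a hydrogen-bond acceptor cannot be told apart from 4-methylphenyl or 4-fluorophenyl. The ring of carbon only is therefore not required to hold the number at this level, and the added acceptor brings no change that can be read here. Within the data shown here, the step of a 2.8-fold higher number from compound 2 to compound 4 (0.45 log units; beyond the scatter) is modest but beyond the scatter, which leaves 2,4-difluorophenyl as the only group among the four whose number stands apart, and compound 2 keeps the lowest number in the set; nothing available explains this difference.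

As far as these compounds go, it remains open whether pyridin-2-yl or pyridin-4-yl would behave as pyridin-3-yl does, and whether a fluoro group on the pyridin-3-yl ring would bring the number towards that of compound 2. Equally open, from the compounds shown here alone, is how a ring carrying an amine or a carboxylic acid, or a saturated ring such as piperidinyl, would read at this place.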